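Swapping chloro for methoxy on a three-ring amidine

A few compounds are considered here, and "the series" means these few. Any claim that something is new, unique, unknown or untested is made for them only; others in the source may bear on it.

Measured so far:
compound 1 `N=C(N)c1ccc(-c2ccc(-c3ccc(F)cc3)s2)cc1`, 1650 nM
compound 2 `N=C(N)c1ccc(-c2ccc(-c3ccc(Cl)cc3)s2)cc1F`, 1500 nM
compound 3 `COc1cc(OC)cc(-c2ccc(-c3ccc(C(=N)N)c(F)c3)s2)c1`, 1370 nM

In a functional assay on BT-549 cells (Homo sapiens) for inhibition, read by sulforhodamine B assay, with a stated time of 48 h (on this read-out higher numbers stand for weaker inhibition of growth and lower numbers for stronger inhibition of growth), the three compounds sit close together. Compound 2 has the second highest of the three numbers, with compound 3 nearest and compound 1 furthest; both gaps lie within the scatter, so no order among them can be claimed.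

Compound 4 `COc1ccc(-c2ccc(-c3ccc(C(=N)N)c(F)c3)s2)cc1` has not yet been tested. Starting from compound 2, the change is methoxy in place of chloro on an aromatic carbon.

Because compound 3, which also carries methoxy groups, gives 1370 nM, a step in this assay of no size beyond the scatter is expected in either direction. Compound 4 is therefore estimated at 1400 nM, within a range from 600 nM to 3500 nM, and the expected step of a 1.1-fold lower number from compound 2 to compound 4 (0.03 log units; within the scatter) is small.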

Compound 4, concentration for 50% growth inhibition: 5900 nM
Compound 4: the middle estimate sits 4.2-fold (0.62 log units) below what was measured, and the stated range ends below it.
By their numbers in this assay, from the lowest: compounds 3, 2 and 1 (each within the scatter of the next); then compound 4.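

In this assay, methoxy in place of chloro gives a 3.9-fold higher number from compound 2 to compound 4 (0.59 log units; beyond the scatter), meaning weaker inhibition of growth. Among the compounds shown here, this is the first comparison here between compounds that differ in one place, and it shows that the group on this aromatic carbon, para to a large group, can matter, which the three closely grouped earlier values could not reveal. Nothing measured here explains the step. On these data alone, whether an amine or a hydroxyl group here would behave more like chloro or like methoxy stays open. So does whether the same swap gives a similar step on the core of compound 1.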